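The source may report more compounds than this note shows. Statements on the series, on what has been measured and on what is new or still open speak of the compounds shown alone.

Measured in a functional assay on HeLa cells (Homo sapiens) for antiproliferative activity, read by MTT assay, with a stated time of 48 h; on this read-out lower numbers stand for stronger inhibition and higher numbers for weaker inhibition:
- compound 1 `Cn1cc(-c2cnc3ccnc(NC(=O)C4CC4)c3c2)cn1`: > 50000 nM
- compound 2 `COc1ccc(C(=O)Nc2nccc3ncc(-c4cnn(C)c4)cc23)cc1`: > 50000 nM

Compound 1 has no number, and its > 50000 nM is a limit. Compound 2 likewise gives only a limit, > 50000 nM. Among the measured compounds shown here, the whole series so far stands at the limit of > 50000 nM in this assay, at which 2 of the 2 values shown sit.

Next is compound 3 `Cn1cc(-c2cnc3ccnc(NCc4ccc(F)cc4)c3c2)cn1`, which differs from compound 1 as follows: 4-fluorobenzyl in place of cyclopropylcarbonyl on a nitrogen on an aromatic ring. In words, this is 4-fluorobenzyl in place of cyclopropylcarbonyl on a nitrogen on an aromatic ring.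

For the measured compounds named here, the only measured step that bears on this change is a step that the two limits leave unreadable from compound 1 to compound 2. It keeps the carbonyl and has no readable size, so it offers no size to carry over. With compound 1 at a limit, a weaker compound 3 would not show in this assay. Only a step toward stronger inhibition could be read, and a small one is expected at most. The expected step is an at least 1.4-fold lower number from compound 1 to compound 3 (0.15 log units; that floor lies within the scatter). A further limit reading remains the likeliest single outcome. For compound 3 the estimate is 35000 nM. The expected range for this compound runs from 8000 nM to 100000 nM.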

Compound 3, half-maximal inhibitory concentration: 9200 nM
For compound 3 the middle estimate is 3.8-fold (0.58 log units) above the measured one; the range from low to high includes it.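

At the nitrogen on an aromatic ring, exchanging cyclopropylcarbonyl for 4-fluorobenzyl gives an at least 5.4-fold lower number from compound 1 to compound 3 (0.73 log units; beyond the scatter) in this assay, so this position can carry a change that reads out on the shared core. On these data alone, compound 1 gives > 50000 nM as a limit and not a number, which makes the printed step a floor whose full size stays unknown. Compound 3 is the only compound shown with a reading inside the range of the assay, and the step from compound 1 to compound 2 cannot be read, so the series gains its first real reference point here, while the rest of it remains at the limit: the limit of > 50000 nM in this assay, at which 2 of the 3 values shown sit.

The change removes the carbonyl and brings in an aromatic ring and a fluorine all at once, so the compounds shown do not tell which of these parts goes with the step. Plain benzyl, a 2-phenylethyl chain or a simple alkyl amine at the same nitrogen would begin to separate these parts, and the ceiling of this series above compound 3 remains open.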